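A few compounds are considered here, and "the series" means these few. Any claim that something is new, unique, unknown or untested is made for them only; others in the source may bear on it.

Measured compounds:
- compound 1 `Nc1nc(NC2CC2)c2ncn(/C=C3/CC3(CO)CO)c2n1`: > 300000 nM
- compound 2 `CCCCCCOc1nc(N)nc2c1ncn2/C=C1/CC1(CO)CO`: > 200000 nM
- compound 3 `CCCCOc1nc(N)nc2c1ncn2/C=C1/CC1(CO)CO`: > 300000 nM

In an ADME assay on HFF cells (Homo sapiens) for cytotoxicity, with a stated time of 8 days (on this read-out lower numbers stand for higher toxicity in this test and higher numbers for lower toxicity in this test), compound 1 gives > 300000 nM, which is a limit of the test rather than a number. Compound 2 also reaches only a limit, > 200000 nM. Compound 3 likewise stands at a limit, > 300000 nM. So compound 1 has no exact position on the scale; it is simply as non-toxic as the test could see, and its two neighbours are the same.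

The unmeasured compound 4 `CCCCSc1nc(N)nc2c1ncn2/C=C1/CC1(CO)CO` differs from compound 1 in one place: butylsulfanyl in place of cyclopropylamino on an aromatic carbon.

Two measured steps change the same cyclopropylamino group on the same aromatic carbon: a step that the two limits leave unreadable from compound 1 to compound 2 and a step that the two limits leave unreadable from compound 1 to compound 3. Both are unreadable, since every value involved is a limit, the limit of > 300000 nM in this assay, at which 2 of the 3 values shown sit, and (the limit of > 200000 nM in this assay, at which 1 of the 3 values shown sits). The third step, a step that the two limits leave unreadable from compound 2 to compound 3, is unreadable for the same reason. Nothing in these data therefore suggests that swapping this group moves this assay out of the non-toxic range, and no step beyond the scatter is expected in this assay.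

Compound 4 is estimated at 300000 nM, in the range 100000 nM to 1000000 nM, meaning an expected step of a number no higher from compound 1 to compound 4 (the limit leaves the size open), with a strong chance that the test again reports only a limit.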

Compound 4, half-maximal cytotoxic concentration: > 300000 nM
Compound 4: no number, only a limit; the forecaster's own chance of this, stated with the estimate: 80%; the middle value lies on the limit itself.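

In this assay compound 4 gives > 300000 nM, which is a limit and not a number, so its steps to compound 1, compound 2 and compound 3 cannot be read. The compounds shown leave open whether butylsulfanyl, butoxy, hexyloxy and cyclopropylamino differ at all in toxicity in this test.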